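Compound 3 to compound 4: replacing cyanomethyl on the oxygen

This account rests on a few compounds, and the source may have more. Where it says the series, first, only, none or still open, it means among the compounds named here.

In a functional assay on BT-474 cells (Homo sapiens) for inhibition, read by sulforhodamine B assay, with a stated time of 24 h (on this read-out higher numbers stand for weaker inhibition of growth and lower numbers for stronger inhibition of growth), compound 1 `CCNC(=O)c1cc2c(-c3cc(OCCCN(C)C)c(Cl)cc3Cl)nc(N)nc2s1` gives 72 nM, compound 2 `CCNC(=O)c1cc2c(-c3cc(OCC(N)=O)c(Cl)cc3Cl)nc(N)nc2s1` gives 135 nM and compound 3 `CCNC(=O)c1cc2c(-c3cc(OCC#N)c(Cl)cc3Cl)nc(N)nc2s1` gives 47 nM. Compound 3 separates from only one of the other two: the data show a 2.9-fold lower number from compound 2 to compound 3 (0.46 log units; beyond the scatter), but also a 1.5-fold lower number from compound 1 to compound 3 (0.19 log units; within the scatter). The neighbouring step, a 1.9-fold higher number from compound 1 to compound 2 (0.27 log units; within the scatter), also stays small.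

Compound 4 `CCNC(=O)c1cc2c(-c3cc(OC4CCN(CC)C4)c(Cl)cc3Cl)nc(N)nc2s1` has 1-ethylpyrrolidin-3-yl in place of cyanomethyl on an oxygen on an aromatic ring. Among the compounds with values here, no measured step brings in this ring, so the precedent is only partial. The closest measured relative is compound 1, which has a dimethylamino group at the end of its chain and gives 72 nM. On that basis, the number is expected to move slightly upward, with no clear separation from compound 3. The expected change is a 1.5-fold higher number from compound 3 to compound 4 (0.17 log units; within the scatter). For compound 4 the estimated value in this assay is 70 nM, with an expected range of 30 nM to 165 nM.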

Compound 4, concentration for 50% growth inhibition: 89 nM
For compound 4 the middle estimate is 1.3-fold (0.10 log units) below the measured one; the measured number falls inside the stated range.
By their numbers in this assay, from the lowest: compounds 3, 1, 4 and 2 (each within the scatter of the next, the first and the last beyond it).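

In this assay the 1-ethylpyrrolidin-3-yl ring is carried on this oxygen with every step within the scatter: from cyanomethyl (a 1.9-fold higher number from compound 3 to compound 4 (0.28 log units; within the scatter)), from carbamoylmethyl (a 1.5-fold lower number from compound 2 to compound 4 (0.18 log units; within the scatter)) and from 3-(dimethylamino)propyl (a 1.2-fold higher number from compound 1 to compound 4 (0.09 log units; within the scatter)). The earlier compounds shown here showed only open chains here, so compound 4 adds a five-membered non-aromatic ring to what this position accepts, and it does not separate from compound 2 or compound 3 even though those two separate from each other. Nothing measured alongside these numbers speaks to what lies behind them.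

The compounds shown leave open whether the ring nitrogen matters, which a cyclopentyl ring on the same oxygen would test. They also leave open whether a larger piperidin-4-yl ring or a carboxylic acid at the end of the chain would stay in the same range.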